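The source may report more compounds than this note shows. Statements on the series, on what has been measured and on what is new or still open speak of the compounds shown alone.

Two compounds have been measured in an ADME assay on TZM cells (Homo sapiens) for cytotoxicity, read by XTT assay, with a stated time of 4 days; a higher number here means that more compound is tolerated, a lower number that less compound is tolerated:

Compound 1 `Cc1cc(/C=C/C#N)cc(C)c1Oc1cc(Nc2ccc(C#N)cc2)c(N)cc1C(F)(F)F`: 15000 nM
Compound 2 `Cc1cc(C#N)cc(C)c1Oc1cc(Nc2ccc(C#N)cc2)c(N)cc1C(F)(F)F`: 13300 nM

In this assay, for the measured compounds named here, compound 2 stands next to compound 1, the only other number: the step of a 1.1-fold lower number from compound 1 to compound 2 (0.05 log units; within the scatter) is the one measured change at this position. Compound 3 `CC(=O)CCc1cc(C)c(Oc2cc(Nc3ccc(C#N)cc3)c(N)cc2C(F)(F)F)c(C)c1` carries the change (2-acetylethyl in place of cyano on an aromatic carbon). Going by the values given here, the only step that bears on it, the exchange at the same aromatic carbon from compound 1 to compound 2, stayed within the scatter, so no step beyond the scatter is expected in this assay for compound 3, as a 1.0-fold lower number from compound 2 to compound 3 (0.01 log units; within the scatter). Compound 3 is therefore estimated at 13000 nM, in the range 6000 nM to 28000 nM.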

Compound 3, half-maximal cytotoxic concentration in the TZM assay: 11100 nM
Compound 3: middle estimate off by 1.2-fold (0.07 log units), on the high side; measured number inside the range.
By their numbers in the TZM assay, from the lowest: compounds 3, 2 and 1 (each within the scatter of the next).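

At this aromatic carbon, a third group, 2-acetylethyl, also leaves the TZM assay within the scatter, with a 1.2-fold lower number from compound 2 to compound 3 (0.08 log units; within the scatter) and a 1.4-fold lower number from compound 1 to compound 3 (0.13 log units; within the scatter). In a physicochemical assay for solubility, with a stated time of 4 h, at pH 7.4 (on this read-out higher numbers stand for higher solubility and lower numbers for lower solubility), compound 2 gives 0.26 ug/mL and compound 3 gives 0.16 ug/mL, which is a 1.6-fold lower number from compound 2 to compound 3 (0.21 log units; within the scatter). No measurement at hand accounts for these results.

On these data alone, whether an amine, a carboxylic acid or a longer chain at this carbon would move either read-out beyond the scatter remains open. So does whether any group here changes these read-outs at all.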